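A Longer Chain on Compound 3: Expecting Compound 4

The compounds below may be only part of what the source reports. "The series", "measured", "known", "first", "only" and "open" are said of these compounds alone.

Compound 1, `CN(C)C1CCN(Cc2ccc(NC(=O)c3ccc(OCCCCl)c([N+](=O)[O-])c3)cc2C(F)(F)F)CC1`, gives 5500 nM in a toxicity assay on Huh-7.5 cells (Homo sapiens) for inhibition, read by MTT assay, with a stated time of 96 h; a higher number here means that more compound is tolerated, a lower number that less compound is tolerated.
Compound 2, `CCC(=O)Nc1cc(C(=O)Nc2ccc(CN3CCN(C)CC3)c(C(F)(F)F)c2)ccc1OCCCCl`, gives 7870 nM in this assay.
Compound 3, `CN1CCN(Cc2ccc(NC(=O)c3ccc(OCCCCl)c([N+](=O)[O-])c3)cc2C(F)(F)F)CC1`, gives 6800 nM in this assay.

Compound 3 has the second highest of the three numbers, and all three sit close together. The change from compound 2 amounts to a 1.2-fold lower number from compound 2 to compound 3 (0.06 log units; within the scatter), and from compound 1 to a 1.2-fold higher number from compound 1 to compound 3 (0.09 log units; within the scatter); neither is beyond the scatter, so these three compounds are indistinguishable in how much of them the cells tolerate.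

Compound 4, `CN1CCN(Cc2ccc(NC(=O)c3ccc(OCCCCCCl)c([N+](=O)[O-])c3)cc2C(F)(F)F)CC1`, is compound 3 with one alteration: 2-chloroethyl in place of chloro on a saturated chain carbon, three bonds along the chain from an oxygen on an aromatic ring. For the measured compounds named here, none of the measured steps touches this chain; they concern the amine on the other side of the core and the group on the aromatic ring. Going by the values given here, there is therefore no measured step that bears on this change, and no step beyond the scatter is expected in this assay. Compound 4 is estimated at 6800 nM, with a range from 3000 nM to 15000 nM. This estimate means a step of no change at the digits printed from compound 3 to compound 4 (within the scatter), which is expected to stay within the scatter.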

Compound 4, half-maximal cytotoxic concentration: 2140 nM
The estimate for compound 4 lay 3.2-fold (0.50 log units) above the measured number; measured number outside the range, below it.
By their numbers in this assay, from the lowest: compound 4; then compounds 1, 3 and 2 (each within the scatter of the next).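

Among the compounds shown, this chain is the only place where a change moves the number beyond the scatter in this assay; the earlier steps, at the amine and at the group on the aromatic ring, stayed within it. Lengthening the 3-chloropropyl chain to 5-chloropentyl gives a 3.2-fold lower number from compound 3 to compound 4 (0.50 log units; beyond the scatter), so the cells tolerate less of the compound with the longer chain, although the step is modest. No measurement shown accounts for this step.

A single step cannot show whether the number falls steadily with length, and a 4-chlorobutyl chain would help to test that. On these data alone, it also remains open whether the terminal chlorine is needed for the drop, which a plain pentyl chain or a 5-hydroxypentyl chain could address.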